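An Ethyl Ester Completes a Pair of Inactive Compounds

This account rests on a few compounds, and the source may have more. Where it says the series, first, only, none or still open, it means among the compounds named here.

compound 1 `CCOC(=O)C1=Cc2ccccc2OC1(OCc1cc(-c2ccc(F)cc2F)no1)C(F)(F)F`: > 150000 nM
compound 2 `O=C(O)C1=Cc2ccccc2OC1(OCc1cc(-c2ccc([N+](=O)[O-])cc2)no1)C(F)(F)F`: > 150000 nM

In a functional assay on A549 cells (Homo sapiens) for inhibition, read by MTT assay, with a stated time of 24 h (on this read-out higher numbers stand for weaker inhibition and lower numbers for stronger inhibition), compound 1 returns only a limit of the assay, > 150000 nM. Compound 2 likewise returns only a limit, > 150000 nM. Neither value is a number, so the two compounds cannot be ordered against each other; all that can be said is that both sit at the limit of > 150000 nM in this assay, at which 2 of the 2 values shown sit. Compound 2 therefore stands nowhere in particular among the numbers shown, since no number has been measured at all.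

Compound 3, `CCOC(=O)C1=Cc2ccccc2OC1(OCc1cc(-c2ccc([N+](=O)[O-])cc2)no1)C(F)(F)F`, is the ethyl ester of compound 2: the change is ethyl in place of hydrogen on an oxygen next to a carbonyl group. The remaining parts of the molecule are unchanged. Among the measured compounds shown here, since no step between measured compounds exists here, the expectation for compound 3 rests only on the two limits already seen. Compound 1 already carries the ethyl ester and still gives only a limit, so no shift beyond the scatter is expected from the step from compound 2 to compound 3, and compound 3 is expected to return a limit as well.

Compound 3 is accordingly estimated at 200000 nM, within 100000 nM to 500000 nM, an expected step that the limit leaves unreadable from compound 2 to compound 3.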

Compound 3, half-maximal inhibitory concentration: > 150000 nM
Compound 3: a limit, no number (the forecaster's own chance of this, stated with the estimate: 85%); the middle value lies beyond the limit too.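

In this assay compound 3 gives > 150000 nM, which is a limit and not a number. No step among compound 1, compound 2 and compound 3 can be read, as all three stop at the same point: the limit of > 150000 nM in this assay, at which 3 of the 3 values shown sit.

The compounds shown leave open whether either ethyl in place of hydrogen or 4-nitrophenyl in place of 2,4-difluorophenyl changes inhibition at all.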